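Second Ring Nitrogen on the Piperazine Aryl Group

The source may hold more compounds than are shown below. What is called first, only, known or untested is meant among the compounds shown, and "the series" means these compounds.

Compound 1 `O=C1c2ccccc2S(=O)(=O)N1CCCCCN1CCN(c2ccc(Cl)cc2)CC1` gives 703 nM in an assay on HEK293 cells for displacement of a labelled ligand from 5-hydroxytryptamine receptor 6 (Homo sapiens); on this read-out lower numbers stand for stronger inhibition and higher numbers for weaker inhibition. Compound 2 `O=C1c2ccccc2S(=O)(=O)N1CCCCCN1CCN(c2ccccn2)CC1` gives 2630 nM in this assay, the higher of the two numbers, and the step of a 3.7-fold higher number from compound 1 to compound 2 (0.57 log units; beyond the scatter) lies beyond the scatter. Compound 3 `O=C1c2ccccc2S(=O)(=O)N1CCCCCN1CCN(c2ncccn2)CC1` differs from compound 2 by pyrimidin-2-yl in place of pyridin-2-yl on an amine nitrogen in a ring. Among the compounds with values here, the only measured step, from 4-chlorophenyl to pyridin-2-yl, weakened binding, so a further modest weakening or no change beyond the scatter is expected for compound 3, a step of a 1.5-fold higher number from compound 2 to compound 3 (0.18 log units; within the scatter). Compound 3 is therefore expected to give 4000 nM in this assay, within a range from 1500 nM to 11000 nM.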

Compound 3, inhibition constant: 7100 nM
For compound 3 the middle estimate is 1.8-fold (0.25 log units) below the measured one, within the range that was stated.
By their numbers in this assay, from the lowest: compound 1; then compound 2; then compound 3.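

Replacing pyridin-2-yl with pyrimidin-2-yl on this amine nitrogen gives a 2.7-fold higher number from compound 2 to compound 3 (0.43 log units; beyond the scatter) in this assay, so a second ring nitrogen weakens binding further. Across these three compounds, the number rises with each ring nitrogen, and going from 4-chlorophenyl to pyrimidin-2-yl gives a 10-fold higher number from compound 1 to compound 3 (1.00 log units; beyond the scatter) overall, although part of that change is the loss of the chlorine. Nothing measured here explains the trend.

As far as these compounds go, a plain phenyl group, with neither chlorine nor ring nitrogen, would help to separate those two changes, and its value remains open.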